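Swapping a triazole linker for a hydroxypiperidine chain

The compounds below may be only part of what the source reports. "The series", "measured", "known", "first", "only" and "open" are said of these compounds alone.

Of the compounds shown here, three sharing one core have been tested in a functional assay on MCF7 cells (Homo sapiens) for cytotoxicity, read by MTT assay, with a stated time of 72 h; a lower number here means a stronger inhibitor, a higher number a weaker inhibitor. Compound 1 `O=C1c2c[n+]([O-])c3ccccc3c2C(=O)c2c1c1ccccc1n2Cc1cn([C@H]2C[C@H](O)[C@@H](CO)O2)nn1` gives 530 nM. Compound 2 `O=C1c2c[n+]([O-])c3ccccc3c2C(=O)c2c1c1ccccc1n2Cc1cn(C[C@@H](O)CO)nn1` gives 600 nM, and these two numbers sit within the scatter of each other, so no order between them can be read. Among the compounds with values here, compound 3 `CC1(C)OC[C@@H](Cn2cc(Cn3c4c(c5ccccc53)C(=O)c3c[n+]([O-])c5ccccc5c3C4=O)nn2)O1` reaches only a limit, > 1000 nM, which means the assay reports no number for it, only that its value lies at the limit of > 1000 nM in this assay, at which 1 of the 3 values shown sits.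

The measured changes are small: a 1.1-fold higher number from compound 1 to compound 2 (0.05 log units; within the scatter), an at least 1.8-fold higher number from compound 1 to compound 3 (0.27 log units; that floor lies within the scatter) and an at least 1.6-fold higher number from compound 2 to compound 3 (0.22 log units; that floor lies within the scatter), all touching the group on the saturated chain carbon bound to the aromatic nitrogen while keeping the triazole ring.

Compound 4 `O=C1c2c[n+]([O-])c3ccccc3c2C(=O)c2c1c1ccccc1n2CCCN1CCC(O)CC1` goes further: 2-(4-hydroxypiperidin-1-yl)ethyl in place of 1-(2,3-dihydroxypropyl)-1H-1,2,3-triazol-4-yl on a saturated chain carbon bound to an aromatic nitrogen. Within the data shown here, no measured step removes the triazole ring, so the three steps bear on this change only in showing that varying the chain so far has moved nothing beyond the scatter. The expectation is therefore a modest shift, a 1.2-fold higher number from compound 2 to compound 4 (0.07 log units; within the scatter), with wide uncertainty. For compound 4 the estimated value in this assay is 700 nM, expected to lie between 250 nM and 2000 nM.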

Compound 4, half-maximal inhibitory concentration: 190 nM
The estimate for compound 4 lay 3.7-fold (0.57 log units) above the measured number, outside the stated range (below it).
By their numbers in this assay, from the lowest: compound 4; then compounds 1 and 2 (each within the scatter of the next). At a limit, above all of these: compound 3.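

Within the data shown here, replacing the 1-(2,3-dihydroxypropyl)-1H-1,2,3-triazol-4-yl group with 2-(4-hydroxypiperidin-1-yl)ethyl on a saturated chain carbon bound to an aromatic nitrogen gives a 3.2-fold lower number from compound 2 to compound 4 (0.50 log units; beyond the scatter) in this assay, the first step in this set printed as beyond the scatter. The earlier steps shown here varied only the group carried on the triazole ring, whereas this one removes that ring, so compound 4 shows that the triazole ring is not required for activity in these cells and that this position can move the number. Nothing available here explains why the number fell.

This single step changes the ring, the length of the chain and the group at its end all at once, so the compounds shown cannot say which of these differences matters. On these data alone, it remains open whether a plain piperidine without the hydroxyl, a morpholine or a dimethylamino group on the same chain would keep the lower number, and whether a shorter or longer chain carrying the 4-hydroxypiperidine would do the same.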